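Cyano to amino: working notes on the series

A few compounds are considered here, and "the series" means these few. Any claim that something is new, unique, unknown or untested is made for them only; others in the source may bear on it.

compound 1 `COc1ccc(Nc2nc(NCCCO)c3ccccc3n2)cc1` 17100 nM
compound 2 `Nc1ccc(Nc2nc(NC3CCCC3)c3ccccc3n2)cc1` 21700 nM
compound 3 `N#Cc1ccc(Nc2nc(NCCCO)c3ccccc3n2)cc1` 4310 nM

In a functional assay on KBVIN cells (Homo sapiens) for antiproliferative activity, read by sulforhodamine B assay, with a stated time of 48 h (a higher number here means a weaker inhibitor of growth, a lower number a stronger inhibitor of growth), compound 3 has the lowest of the three numbers, beyond the scatter from both others, with compound 1 nearest and compound 2 furthest. The next compound to consider is compound 4 `Nc1ccc(Nc2nc(NCCCO)c3ccccc3n2)cc1`, which carries amino in place of cyano on an aromatic carbon. Within the data shown here, no measured step exchanges these two groups directly. Among the measured compounds shown here, the one step that bears on the change is modest: a 4.0-fold lower number from compound 1 to compound 3 (0.60 log units; beyond the scatter), with cyano in place of methoxy on an aromatic carbon. Losing the cyano group may therefore reverse much of that gain, so a step of comparable size towards a higher number is expected in this assay, although this rests on a single pair. The expected step is a 3.2-fold higher number from compound 3 to compound 4 (0.51 log units; beyond the scatter), which would lie beyond the scatter. For compound 4 the estimated value is 14000 nM, with an expected range of 6000 nM to 32000 nM.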

Compound 4, concentration for 50% growth inhibition: 18700 nM
Estimate against measurement, compound 4: 1.3-fold (0.13 log units) below, and the stated range covers the measured number.
By their numbers in this assay, from the lowest: compound 3; then compounds 1, 4 and 2 (each within the scatter of the next).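

In this assay, among these compounds, exchanging cyano for amino gives a 4.3-fold higher number from compound 3 to compound 4 (0.64 log units; beyond the scatter), whereas exchanging methoxy for amino gives a 1.1-fold higher number from compound 1 to compound 4 (0.04 log units; within the scatter), so at this place on the aromatic ring, para to a large group, cyano is the only one of the three groups set apart by a step beyond the scatter. With amino held fixed, the change on the nitrogen gives a 1.2-fold lower number from compound 2 to compound 4 (0.06 log units; within the scatter), so 3-hydroxypropyl and cyclopentyl cannot be told apart in this pair. No evidence on the origin of these steps is available.

The compounds shown leave open whether a carboxylic acid or a chlorine atom at this place would align with cyano or with amino and methoxy. They also leave open whether cyano keeps its separation when cyclopentyl or a longer chain stands on the nitrogen.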